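A few compounds are considered here, and "the series" means these few. Any claim that something is new, unique, unknown or untested is made for them only; others in the source may bear on it.

Measured in a functional assay on PC-12 cells (Rattus norvegicus) for cytotoxicity, read by MTT assay, with stated times of 3 h and 2 h, tested at 50 uM; on this read-out lower numbers stand for a weaker effect and higher numbers for a stronger effect at the one concentration tested:

Compound 1, `O=C(CCCCC1CCSS1)NCc1cn(CCCOc2ccc3ccc(=O)oc3c2)nn1`: 43.5%
Compound 2, `O=C(CCCCC1CCSS1)NCc1cn(CCCOc2ccc3cc(-c4ccccc4)c(=O)oc3c2)nn1`: 23.1%
Compound 3, `O=C(CCCCC1CCSS1)NCc1cn(CCCCOc2ccc3ccc(=O)oc3c2)nn1`: 75.8%

Among the compounds with values here, the one change seen twice in this small set is phenyl in place of hydrogen on an aromatic carbon. Made on the core of compound 1 it gave a number 20.4 percentage points lower from compound 1 to compound 2 (beyond the scatter), a drop that lies beyond the scatter but is modest in size. Compound 3 carries a different core; the difference between the two cores is not broken down here. On this read-out compound 3 stands highest of the three numbers, with compound 1 the nearest and compound 2 the furthest, both gaps beyond the scatter.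

Compound 4, `O=C(CCCCC1CCSS1)NCc1cn(CCCCOc2ccc3cc(-c4ccccc4)c(=O)oc3c2)nn1`, has not yet been measured. It differs from compound 3 by phenyl in place of hydrogen on an aromatic carbon, which is the same change as between compound 1 and compound 2, at a place described in the same words. The expectation for compound 4 therefore rests on the step from compound 1 to compound 2 alone, applied to the higher starting number of compound 3.

Within the data shown here, for compound 4 the estimated step is a number 20.8 percentage points lower from compound 3 to compound 4 (beyond the scatter), taken as similar in size to the measured one because a number 20.4 percentage points lower from compound 1 to compound 2 (beyond the scatter) is the only guide available. The value of compound 4 in this assay is accordingly estimated at 55%, with a likely range from 35% to 72%, the width reflecting that a single measured step from a different core supports it.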

Compound 4, a percentage reported as activity, at one concentration (the size of the read-out at that concentration, not a potency): 20.5%
Compound 4: middle estimate off by 34.5 percentage points, on the high side; the measured number lies below the stated range.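

Phenyl in place of hydrogen on an aromatic carbon gave a number 55.3 percentage points lower from compound 3 to compound 4 (beyond the scatter) in this assay. Set beside the earlier step, the direction of the change carries over between the two cores, but its size does not: the same change on two cores in this assay, a number 20.4 percentage points lower (beyond the scatter) from compound 1 to compound 2 and a number 55.3 percentage points lower (beyond the scatter) from compound 3 to compound 4, 34.9 percentage points apart, beyond the scatter of two such steps

Within the data shown here, with only one pair on each core, the direction holds for these two cores alone, and the size of the step on one core proved a poor guide to its size on the other; the data do not show which feature of the cores goes with the difference, or what size the step would take on any further core.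

Still open, going by these compounds, is whether the dependence on the core is tied to the phenyl group itself, which a methyl group or a chlorine atom on the same aromatic carbon of each core would help to settle. Also open is how the step behaves on a core with a longer chain than those shown, and whether the pattern seen at the single tested concentration would persist across a range of concentrations.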